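The source may hold more compounds than are shown below. What is called first, only, known or untested is meant among the compounds shown, and "the series" means these compounds.

Compound 1: `COc1cc(/C=C/C(=O)c2cccc(NC(=O)C(C)C)c2)ccc1O` gives 1.09 ug/mL in a functional assay on B16 cells (Mus musculus) for inhibition; on this read-out higher numbers stand for weaker inhibition and lower numbers for stronger inhibition.
Compound 2: `COc1cc(/C=C/C(=O)c2cccc(NC(=O)c3cc(Cl)cc(Cl)c3)c2)ccc1O` gives 4.83 ug/mL in this assay.

Going by the values given here, compound 2 has the highest of the two numbers, with compound 1 the only neighbour, a step of a 4.4-fold higher number from compound 1 to compound 2 (0.65 log units; beyond the scatter). Compound 3, `COC(=O)C(=O)Nc1cccc(C(=O)/C=C/c2ccc(O)c(OC)c2)c1`, differs from compound 2 by methoxycarbonyl in place of 3,5-dichlorophenyl on a carbonyl carbon. Among the compounds with values here, only that one step is known, and it concerns a different group entering at this place, so it gives a weak guide; no measured step covers the methoxycarbonyl. Compound 3 is therefore expected to show a step of a 2.4-fold lower number from compound 2 to compound 3 (0.38 log units; beyond the scatter), a somewhat lower number. The estimate for compound 3 is 2 ug/mL, within 0.7 ug/mL to 6 ug/mL.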

Compound 3, half-maximal inhibitory concentration: 4.41 ug/mL
Compound 3: the middle estimate sits 2.2-fold (0.34 log units) below what was measured; the measured number falls inside the stated range.
By their numbers in this assay, from the lowest: compound 1; then compounds 3 and 2 (each within the scatter of the next).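

In this assay, the step of a 1.1-fold lower number from compound 2 to compound 3 (0.04 log units; within the scatter) shows that an aromatic ring is not needed at this carbonyl carbon for this level of inhibition: the ring-free methoxycarbonyl and the larger 3,5-dichlorophenyl read alike. The step of a 4.0-fold higher number from compound 1 to compound 3 (0.61 log units; beyond the scatter) places both groups on the same side of isopropyl, which so far gives the stronger inhibition. Nothing measured here accounts for this. The compounds shown leave open whether other small carbon-only groups, such as methyl or cyclopropyl, would match isopropyl, and how an amine or a carboxylic acid would read here.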